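The compounds below may be only part of what the source reports. "The series", "measured", "known", "first", "only" and "open" are said of these compounds alone.

Measured compounds:
compound 1 `CC(C)n1c(/C=C2\SC(=O)N(CC(=O)N3CCCC3)C2=O)nc2ccccc21`: > 50000 nM
compound 2 `Cn1c(/C=C2\SC(=O)N(CC(=O)N3CCCC3)C2=O)nc2ccccc21`: > 50000 nM
compound 3 `CC1CN(C(=O)CN2C(=O)S/C(=C\c3nc4ccccc4n3C)C2=O)CC(C)O1`: > 50000 nM

In a functional assay on PC-3 cells (Homo sapiens) for inhibition, read by MTT assay, with a stated time of 48 h (on this read-out lower numbers stand for stronger inhibition and higher numbers for weaker inhibition), compound 1 gives > 50000 nM, a limit of the assay rather than a number. Compound 2 gives > 50000 nM in this assay, also a limit. Compound 3 gives > 50000 nM in this assay, again a limit; all three values sit at the limit of > 50000 nM in this assay, at which 3 of the 3 values shown sit.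

The change from compound 2 to compound 1 is isopropyl in place of methyl on an aromatic nitrogen. The cores of compound 3 and compound 2 differ by 2,6-dimethylmorpholin-4-yl in place of pyrrolidin-1-yl on a carbonyl carbon, with the step that the two limits leave unreadable from compound 2 to compound 3.

Compound 4 `CC1CN(C(=O)CN2C(=O)S/C(=C\c3nc4ccccc4n3C(C)C)C2=O)CC(C)O1` is not yet measured; it differs from compound 3 by isopropyl in place of methyl on an aromatic nitrogen, the same change already seen between compound 2 and compound 1. Beside the earlier step that the two limits leave unreadable from compound 2 to compound 1, the step from compound 3 to compound 4 is expected to be a step that the limit leaves unreadable from compound 3 to compound 4, resting on the fact that compound 3 shows only the limit > 50000 nM. Compound 4 is accordingly estimated at 60000 nM, between 30000 nM and 200000 nM, most likely reported as a limit only.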

Compound 4, half-maximal inhibitory concentration: > 50000 nM
Compound 4: a limit, no number; the forecaster's own chance of this, stated with the estimate: 85%; the middle value lies beyond the limit too.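

Neither step into compound 4, from compound 3 or from compound 1, can be read, since compound 4 and both neighbours sit at the same limit: the limit of > 50000 nM in this assay, at which 4 of the 4 values shown sit. The compounds shown leave open which change, if any, would give a measurable value in this assay.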